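The source may report more compounds than this note shows. Statements on the series, on what has been measured and on what is new or still open speak of the compounds shown alone.

Measured in a functional assay on PC-12 cells (Rattus norvegicus) for cytotoxicity, read by MTT assay, with a stated time of 24 h, tested at 1 uM; on this read-out higher numbers stand for a stronger effect at the one concentration tested and lower numbers for a weaker effect:
compound 1, `COc1ccc(C(c2ccc(OC)cc2)N2CCN(C(=O)COc3ccc4ccccc4c3)CC2)cc1`: 5.42%
compound 2, `COc1ccc(OCC(=O)N2CCN(C(c3ccc(F)cc3)c3ccc(F)cc3)CC2)cc1`: 5.26%
compound 3, `COc1ccc(OCC(=O)N2CCN(C(c3ccc(C)cc3)c3ccc(C)cc3)CC2)cc1`: 42.3%

In this assay compound 1 stands second highest of the three numbers; its nearest neighbour is compound 2, whose value lies within the scatter of that of compound 1, while compound 3 sits well beyond it. Compound 4, `COc1ccc(OCC(=O)N2CCN(C(c3ccc(OC)cc3)c3ccc(OC)cc3)CC2)cc1`, has not yet been measured. It differs from compound 1 in one place: 4-methoxyphenyl in place of naphthalen-2-yl on an oxygen on a saturated carbon. Compound 4 shares its 4-methoxyphenoxy part with compound 2 and compound 3. The step from compound 1 to compound 4 is expected to be small in this assay, upward if anything, and not clearly beyond the scatter, as a number 4.6 percentage points higher from compound 1 to compound 4 (within the scatter). Compound 4 is therefore estimated at 10%, between 0% and 35%.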

Compound 4, a percentage reported as activity, at one concentration (the size of the read-out at that concentration, not a potency): 80.7%
Beside the measured number, compound 4's estimate is 70.7 percentage points below it; the measured number lies above the stated range.
By their numbers in this assay, from the lowest: compounds 2 and 1 (each within the scatter of the next); then compound 3; then compound 4.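

Within the data shown here, the change of naphthalen-2-yl to 4-methoxyphenyl on an oxygen on a saturated carbon gives in this assay a large step, a number 75.3 percentage points higher from compound 1 to compound 4 (beyond the scatter), the first single-place comparison. It shows that this position is far from silent at the one concentration tested: replacing the two-ring group with the one-ring methoxy-bearing group alone separates the pair well beyond the scatter. No accompanying measurement bears on what lies behind this step. The compounds shown leave open whether plain phenyl or 4-hydroxyphenyl at this place would give a similar number. They also leave open whether the same exchange would give a step of this size with 4-fluorophenyl or 4-methylphenyl groups on the core.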